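Swapping allyloxy for chloro on compound 2

The source may report more compounds than this note shows. Statements on the series, on what has been measured and on what is new or still open speak of the compounds shown alone.

Measured in an ADME assay on KB cells (Homo sapiens) for cytotoxicity, read by MTT assay, with a stated time of 72 h (a higher number here means a weaker inhibitor, a lower number a stronger inhibitor), so far:
Compound 1 `COc1ccc(C2=C(c3cc(OC)c(OC)c(OC)c3)C(=O)C(OC(C)=O)C2)cc1OC(C)C` gives > 100 ug/mL as a limit
Compound 2 `C=CCOc1cc(C2=C(c3cc(OC)c(OC)c(OC)c3)C(=O)C(O)C2)ccc1OC` gives > 100 ug/mL as a limit
Compound 3 `COc1ccc(C2=C(c3cc(OC)c(OC)c(OC)c3)C(=O)C(OC(C)=O)C2)cc1F` gives 33 ug/mL as a number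

Compound 2 stands at > 100 ug/mL as a limit and not a number. Compound 4 `COc1ccc(C2=C(c3cc(OC)c(OC)c(OC)c3)C(=O)C(O)C2)cc1Cl` has chloro in place of allyloxy on an aromatic carbon and is otherwise the same as compound 2. The closest guide is an at least 3.0-fold lower number from compound 1 to compound 3 (0.48 log units; beyond the scatter) with fluoro in place of isopropoxy on an aromatic carbon, a step beyond the scatter. Its groups and the rest of its core differ from this pair, so it is only a rough guide. A lower number is therefore expected in this assay here too. The expected step is an at least 2.5-fold lower number from compound 2 to compound 4 (0.39 log units; beyond the scatter) in size. For compound 4 the estimated value is 40 ug/mL with an expected range from 12 ug/mL to 100 ug/mL in this assay.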

Compound 4, half-maximal inhibitory concentration: 2.5 ug/mL
For compound 4 the middle estimate is 16-fold (1.20 log units) above the measured one; measured number outside the range, below it.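

In this assay, chloro in place of allyloxy gives an at least 40-fold lower number from compound 2 to compound 4 (1.60 log units; beyond the scatter). So a change at this aromatic carbon, ortho to a methoxy group, also lowers the number on the core carrying a hydroxyl, not only on the acetoxy core of compound 1 and compound 3. The full size of the step cannot be read, because compound 2 sits at a limit and not at a number: the limit of > 100 ug/mL in this assay, at which 2 of the 4 values shown sit.

Going by these compounds, whether an amine or a methyl group at this carbon would match chloro stays open. So does how chloro would behave on the acetoxy core.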